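Cyclohexylmethoxy homologue of the ethoxy thiosemicarbazone

A few compounds are considered here, and "the series" means these few. Any claim that something is new, unique, unknown or untested is made for them only; others in the source may bear on it.

Compound 3 `CCOc1ccc(/C=N/NC(N)=S)c2ccccc12` was read in a toxicity assay on MRC5 cells (Homo sapiens) for cytotoxicity, read by MTT assay, with a stated time of 72 h (on this read-out higher numbers stand for an effect only at larger amounts of compound and lower numbers for an effect already at smaller amounts), only as a limit, > 200000 nM. Compound 1 `NC(=S)N/N=C/c1cn(CCCc2ccccc2)c2ccccc12` likewise returned only a limit in this assay, > 200000 nM. Compound 2 `Cc1ccc(/C=N/NC(N)=S)c2ccccc12` gave a number in this assay, 37000 nM. Within the data shown here, the one measured step, an at least 5.4-fold higher number from compound 2 to compound 3 (0.73 log units; beyond the scatter), is open-ended because it rests on (the limit of > 200000 nM in this assay, at which 2 of the 3 values shown sit). Compound 4 `NC(=S)N/N=C/c1ccc(OCC2CCCCC2)c2ccccc12` differs from compound 3 by cyclohexyl in place of methyl on a saturated chain carbon bound to an oxygen on an aromatic ring. Among the measured compounds shown here, no measured step covers this change; the only step in hand runs from methyl to ethoxy, and the larger alkoxy group of compound 4 has no precedent. For compound 4 a step of a number no higher from compound 3 to compound 4 (the limit leaves the size open) is therefore expected, most likely again ending at a limit. The estimate for compound 4 in this assay is 200000 nM, from 50000 nM to 600000 nM.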

Compound 4, half-maximal effective concentration: 28900 nM
Compound 4: middle estimate off by 6.9-fold (0.84 log units), on the high side; measured number below the stated range.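

In this assay the alkoxy position proves able to shift the read-out: an at least 6.9-fold lower number from compound 3 to compound 4 (0.84 log units; beyond the scatter), with ethoxy replaced by cyclohexylmethoxy. Going by these compounds, the size of that step stays open, since it starts from a limit: the limit of > 200000 nM in this assay, at which 2 of the 4 values shown sit. Against the methyl group on the same aromatic carbon, a 1.3-fold lower number from compound 2 to compound 4 (0.11 log units; within the scatter), so an alkoxy group there does not always end at a limit.

On these data alone, whether the cyclohexyl ring itself or merely a longer chain drives this remains open. A straight hexyloxy chain or a benzyloxy group would separate the two, and neither is among the compounds shown.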